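The source may report more compounds than this note shows. Statements on the series, on what has been measured and on what is new or still open speak of the compounds shown alone.

Compound 3 `N#CC1CN1C(=O)Nc1ccccc1` gives 8000 nM in a functional assay on RPMI-8226 cells (Homo sapiens) for inhibition (on this read-out lower numbers stand for stronger inhibition and higher numbers for weaker inhibition), and carries the lowest of the three numbers, yet it sits within the scatter of both others: compound 2 `N#CC1CN1C(=O)Nc1ccc([N+](=O)[O-])cc1` gives 8600 nM and compound 1 `N#CC1CN1C(=O)Nc1ccc(Cl)cc1Cl` gives 9400 nM in this assay. Compound 4 `N#CC1CN1C(=O)Nc1ccc(S(N)(=O)=O)cc1` differs from compound 3 by sulfamoyl in place of hydrogen on an aromatic carbon. Within the data shown here, the one step that bears on this change, a substituent exchange on the same aromatic ring, is a 1.1-fold lower number from compound 2 to compound 3 (0.03 log units; within the scatter), which is flat. Compound 1 and compound 3 differ in two places and only their two values can be compared; they too lie within the scatter. On this basis the step from compound 3 to compound 4 is expected to stay within the scatter: a 1.1-fold higher number from compound 3 to compound 4 (0.03 log units; within the scatter). For compound 4 in this assay the estimate is 8500 nM, ranging from 3500 nM to 20000 nM.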

Compound 4, half-maximal inhibitory concentration: > 38000 nM
Compound 4 gave a limit, no number; the forecaster's own chance of this, stated with the estimate: 10%; middle value at least 4.4-fold (0.65 log units) from the limit.
By their numbers in this assay, from the lowest: compounds 3, 2 and 1 (each within the scatter of the next). At a limit, above all of these: compound 4.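

At this position on the aromatic ring the substituent is not indifferent: sulfamoyl in place of hydrogen gives an at least 4.7-fold higher number from compound 3 to compound 4 (0.67 log units; beyond the scatter), and sulfamoyl in place of nitro gives an at least 4.4-fold higher number from compound 2 to compound 4 (0.64 log units; beyond the scatter), whereas the exchange of nitro and hydrogen stayed flat, with a 1.1-fold lower number from compound 2 to compound 3 (0.03 log units; within the scatter). Hydrogen and nitro are thus tolerated alike here, and sulfamoyl is not. Compound 4 gives a limit and no number, so both new steps are lower bounds: the limit of > 38000 nM in this assay, at which 1 of the 4 values shown sits.

As far as these compounds go, how far compound 4 lies past this limit stays open. Also open, from the compounds shown here alone, is whether an amine, a carboxylic acid or a methyl sulfone at this position would read like sulfamoyl or like nitro.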